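Tetrazole to carboxylic acid in the hydroxyacetophenone series

This account rests on a few compounds, and the source may have more. Where it says the series, first, only, none or still open, it means among the compounds named here.

Compound 1 `CCCc1c(COc2ccc(C(=O)Cc3nnn[nH]3)cc2)ccc(C(C)=O)c1O`: 24.1 mg/kg
Compound 2 `CCCc1c(COc2ccc(C(=O)C(C)Cc3nnn[nH]3)cc2)ccc(C(C)=O)c1O`: 9.2 mg/kg

Within the data shown here, in an in vivo functional assay on the whole organism (Rattus norvegicus) with cysteinyl leukotriene receptor (Homo sapiens) as the target (on this read-out lower numbers stand for an effect already at smaller amounts and higher numbers for an effect only at larger amounts of compound), compound 2 gives 9.2 mg/kg, the lowest of the two numbers so far; the only other point is compound 1 at 24.1 mg/kg, and the step of a 2.6-fold lower number from compound 1 to compound 2 (0.42 log units; beyond the scatter) came from the branching at the carbonyl carbon. Compound 3 `CCCc1c(COc2ccc(C(=O)CCCC(=O)O)cc2)ccc(C(C)=O)c1O` differs from compound 2 as follows: 3-carboxypropyl in place of 1-((1H-tetrazol-5-yl)methyl)ethyl on a carbonyl carbon. Among the measured compounds shown here, no measured step covers this exchange, and the branch that gave the gain in compound 2 is removed, so the expectation is a modest step back, a 2.7-fold higher number from compound 2 to compound 3 (0.43 log units; beyond the scatter), placing compound 3 at about 25 mg/kg, estimated between 8 mg/kg and 80 mg/kg.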

Compound 3, dose for half-maximal effect: 9.5 mg/kg
Compound 3: the middle estimate sits 2.6-fold (0.42 log units) above what was measured; the range from low to high includes it.
By their numbers in this assay, from the lowest: compounds 2 and 3 (each within the scatter of the next); then compound 1.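

In this assay the open 3-carboxypropyl chain on the carbonyl carbon stands level with the 1-((1H-tetrazol-5-yl)methyl)ethyl group, at a 1.0-fold higher number from compound 2 to compound 3 (0.01 log units; within the scatter) in this pair, so the five-membered aromatic ring is not required for this read-out in these compounds. Against the unbranched tetrazole, the exchange gives a 2.5-fold lower number from compound 1 to compound 3 (0.40 log units; beyond the scatter) without any branch on the chain. No data here explain either result.

Still open, on these data alone, is how a 4-carboxybutyl chain or an amine would read on this carbonyl carbon. The effect of a methyl branch on the 3-carboxypropyl chain is equally unknown.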